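Compound 4 Sets 3,4-Dihydroxyphenyl Against Trimethoxyphenyl

A few compounds are considered here, and "the series" means these few. Any claim that something is new, unique, unknown or untested is made for them only; others in the source may bear on it.

Compound 1 `COc1cc([C@@H]2[C@H](Oc3ccccc3)C(=O)N2c2cc(OC)c(OC)c(OC)c2)cc(OC)c1OC` is the reference point of this set. In a functional assay on MCF7 cells (Homo sapiens) for antiproliferative activity, read by MTT assay, with stated times of 24 h and 72 h (on this read-out lower numbers stand for stronger inhibition and higher numbers for weaker inhibition), compound 1 gives 29000 nM, the lowest of the three numbers measured. Compound 2 `COc1cc(N2C(=O)[C@@H](Oc3ccccc3)[C@H]2c2ccc3ccccc3c2)cc(OC)c1OC` carries a naphthalen-2-yl group on the same saturated ring carbon and gives 282000 nM, while compound 3 `COc1cc(N2C(=O)[C@@H](Oc3ccccc3)[C@H]2c2ccc(S(C)(=O)=O)cc2)cc(OC)c1OC` carries a 4-(methylsulfonyl)phenyl group there and gives 62000 nM. The two measured exchanges at this carbon both raised the number: a 9.7-fold higher number from compound 1 to compound 2 (0.99 log units; beyond the scatter) and a 2.1-fold higher number from compound 1 to compound 3 (0.33 log units; beyond the scatter), and between the two replacements a 4.5-fold lower number from compound 2 to compound 3 (0.66 log units; beyond the scatter).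

Compound 4 `COc1cc(N2C(=O)[C@@H](Oc3ccccc3)[C@H]2c2ccc(O)c(O)c2)cc(OC)c1OC` is the next exchange at the same position, (3,4-dihydroxyphenyl in place of 3,4,5-trimethoxyphenyl on a saturated ring carbon). Both earlier replacements of the 3,4,5-trimethoxyphenyl group bear on it, since each weakened inhibition, one modestly and one more clearly. With no measured replacement in this series ever lowering the number, compound 4 is expected to sit somewhat higher than compound 1, probably closer to the smaller of the two earlier steps, so the expected step is a 2.1-fold higher number from compound 1 to compound 4 (0.32 log units; beyond the scatter). The estimate for compound 4 in this assay is therefore 60000 nM, with a range from 25000 nM to 200000 nM, acknowledging that the number of comparisons available is small.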

Compound 4, half-maximal inhibitory concentration: 4500 nM
For compound 4 the middle estimate is 13-fold (1.12 log units) above the measured one; measured number outside the range, below it.
By their numbers in this assay, from the lowest: compound 4; then compound 1; then compound 3; then compound 2.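

Every earlier exchange of the 3,4,5-trimethoxyphenyl group on this saturated ring carbon had raised the number in this assay, but 3,4-dihydroxyphenyl reverses the direction, with a 6.4-fold lower number from compound 1 to compound 4 (0.81 log units; beyond the scatter) in the same exchange. The 3,4,5-trimethoxyphenyl group is therefore not required for the lowest number in this set, and the position proves more sensitive than the first three compounds showed, with a 14-fold lower number from compound 3 to compound 4 (1.14 log units; beyond the scatter) and a 63-fold lower number from compound 2 to compound 4 (1.80 log units; beyond the scatter) against the two other replacements. The change also brings in 2 hydrogen-bond donors where the departing group has 0, but nothing available explains the lower number, and the effects of adding hydroxyl groups and losing methoxy groups cannot be separated here.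

On these data alone, it remains open whether a 4-hydroxyphenyl group, with its single hydroxyl, or a 3,4-diaminophenyl group would keep the number as low as compound 4 does. As far as these compounds go, it is also open whether the 3,4-dihydroxyphenyl gain would survive if a carboxylic acid or an amine took the place of the phenoxy group on the neighbouring ring atom.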